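Fluoro for methyl on the benzyl sulfide of compound 3

The source may report more compounds than this note shows. Statements on the series, on what has been measured and on what is new or still open speak of the compounds shown alone.

The series shares one core and varies only the group on the sulfur. Compound 1 `O=c1c2ccccc2[se]n1-c1nc(SCc2ccccc2)n[nH]1` is assessed in a functional assay on A549 cells (Homo sapiens) for antiproliferative activity, read by CCK-8 assay, with a stated time of 48 h; a higher number here means a weaker inhibitor, a lower number a stronger inhibitor; in this assay compound 1 reports only the assay limit of > 50000 nM. Compound 2 `CCCCSc1n[nH]c(-n2[se]c3ccccc3c2=O)n1` gives 12500 nM in this assay. Compound 3 `Cc1ccc(CSc2n[nH]c(-n3[se]c4ccccc4c3=O)n2)cc1` again reports only the limit, > 50000 nM, in this assay. The step of an at least 4.0-fold lower number from compound 1 to compound 2 (0.60 log units; beyond the scatter) and the step of an at least 4.0-fold higher number from compound 2 to compound 3 (0.60 log units; beyond the scatter) both show the butyl sulfide ahead of the benzyl sulfides, while the step that the two limits leave unreadable from compound 1 to compound 3 cannot be sized, since the limit of > 50000 nM in this assay, at which 2 of the 3 values shown sit, covers both ends of it.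

Compound 4 `O=c1c2ccccc2[se]n1-c1nc(SCc2ccc(F)cc2)n[nH]1` differs from compound 3 by fluoro in place of methyl on an aromatic carbon. Among the compounds with values here, the one measured step at this very place is a step that the two limits leave unreadable from compound 1 to compound 3, which is unreadable, and neither hydrogen nor methyl there moved compound 1 or compound 3 off the limit. Compound 4 is therefore expected to stay near the limit, with an estimated step of a number no higher from compound 3 to compound 4 (the limit leaves the size open). The estimate for compound 4 in this assay is 50000 nM, within 15000 nM to 150000 nM.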

Compound 4, half-maximal inhibitory concentration: 36400 nM
Compound 4: middle estimate off by 1.4-fold (0.14 log units), on the high side; the range from low to high includes it.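

Compound 4 gives 36400 nM in this assay, making it the only benzyl sulfide shown with a number rather than a limit, and that number turns the lead of the butyl sulfide into a measured gap: a 2.9-fold higher number from compound 2 to compound 4 (0.46 log units; beyond the scatter). At the aromatic carbon itself, the readings are an at least 1.3-fold lower number from compound 3 to compound 4 (0.13 log units; that floor lies within the scatter) and an at least 1.3-fold lower number from compound 1 to compound 4 (0.13 log units; that floor lies within the scatter), so fluoro cannot be ranked against methyl or hydrogen. Those two steps remain floors because the values of compound 1 and compound 3 are limits: the limit of > 50000 nM in this assay, at which 2 of the 4 values shown sit.

What the compounds shown leave open is how a chloro, a methoxy or a carboxylic acid would read at this aromatic carbon. They also leave open whether a chain longer than butyl on the sulfur would give a lower number than compound 2.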